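Trifluoromethyl for methyl on the thiophene-fused core

This account rests on a few compounds, and the source may have more. Where it says the series, first, only, none or still open, it means among the compounds named here.

Measured compounds:
compound 1 `CC#C[C@@H](Cc1nnn[nH]1)c1ccc(OCc2ccc3sc(F)c(-c4ccccc4C)c3c2)cc1`, 15 nM
compound 2 `CC#C[C@@H](Cc1nnn[nH]1)c1ccc(OCc2ccc3sc(C)c(-c4ccc(OCCOC)cc4C)c3c2)cc1`, 47 nM
compound 3 `CC#C[C@@H](Cc1nnn[nH]1)c1ccc(OCc2ccc3sc(C#N)c(-c4ccccc4C)c3c2)cc1`, 16 nM

In a functional assay on cells for agonist activity at Free fatty acid receptor 1 (Homo sapiens), read by FLIPR and calcium flux (on this read-out lower numbers stand for an effect already at smaller amounts and higher numbers for an effect only at larger amounts of compound), compound 2 gives the highest of the three numbers; compound 3 lies lower, and compound 1 lower still, both beyond the scatter. The untested compound 4 `CC#C[C@@H](Cc1nnn[nH]1)c1ccc(OCc2ccc3sc(C(F)(F)F)c(-c4ccc(OCCOC)cc4C)c3c2)cc1` arises from compound 2 by the change (trifluoromethyl in place of methyl on an aromatic carbon). Among the measured compounds shown here, the only measured step at this position, a 1.1-fold higher number from compound 1 to compound 3 (0.03 log units; within the scatter), changed the number by an amount within the scatter, so substituent changes here have so far mattered little. For the measured compounds named here, compound 2 differs from compounds 1 and 3 in two places, so no single step isolates the methyl. Compound 4 is therefore expected to show a 1.2-fold lower number from compound 2 to compound 4 (0.07 log units; within the scatter), a change not clearly beyond the scatter, with an estimated value of 40 nM (15 nM to 120 nM).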

Compound 4, half-maximal effective concentration: 13 nM
The estimate for compound 4 lay 3.1-fold (0.49 log units) above the measured number; the whole stated range lies above it.
By their numbers in this assay, from the lowest: compounds 4, 1 and 3 (each within the scatter of the next); then compound 2.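

In this assay, trifluoromethyl in place of methyl gives a 3.6-fold lower number from compound 2 to compound 4 (0.56 log units; beyond the scatter), so a substituent on this carbon next to the ring sulfur can shift the number beyond the scatter, which cyano in place of fluoro, at a 1.1-fold higher number from compound 1 to compound 3 (0.03 log units; within the scatter), did not show. The two steps were read on compounds with different aryl groups at the neighbouring ring atom, so their sizes cannot be set directly against each other. Nothing shown accounts for the size of the new step. From the compounds shown here alone, whether trifluoromethyl has the same effect alongside the unsubstituted 2-methylphenyl group of compound 1 remains open. So does the effect of an amine or a carboxylic acid at this position.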